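The compounds below may be only part of what the source reports. "The series", "measured", "known", "first", "only" and "open" are said of these compounds alone.

Compound 1 `CCCCCc1cc(-c2cn([C@H]3C[C@H](OC(C)=O)[C@@H](COC(C)=O)O3)c(=O)[nH]c2=O)on1`: 99.8%
Compound 2 `CC(=O)OC[C@H]1O[C@@H](n2cc(-c3cc(-c4ccccc4)no3)c(=O)[nH]c2=O)C[C@@H]1OC(C)=O`: 97.6%

Within the data shown here, in a functional assay on ACHN cells (Homo sapiens) for cytotoxicity, read by sulforhodamine B assay, tested at 10 uM (on this read-out higher numbers stand for more inhibition at the one concentration tested (going by the name of the read-out) and lower numbers for less inhibition), compound 2 holds the lower of the two numbers, and the only step between them, a number 2.2 percentage points lower from compound 1 to compound 2 (within the scatter), lies within the scatter. Compound 3 `CCc1ccc(-c2cc(-c3cn([C@H]4C[C@H](OC(C)=O)[C@@H](COC(C)=O)O4)c(=O)[nH]c3=O)on2)cc1` carries the change (ethyl in place of hydrogen on an aromatic carbon). Among the measured compounds shown here, the single measured step bears on it only as a sign that the number in this assay stays level for the shared core whichever group sits on that aromatic carbon. No step beyond the scatter is therefore expected. Compound 3 is expected to give 97%, within 90% to 100%, an estimated step of a number 0.6 percentage points lower from compound 2 to compound 3 (within the scatter).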

Compound 3, a percentage reported as inhibition, at one concentration (the size of the read-out at that concentration, not a potency): 92%
The estimate for compound 3 lay 5 percentage points above the measured number; the measured number falls inside the stated range.
By their numbers in this assay, from the lowest: compounds 3, 2 and 1 (each within the scatter of the next).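

With ethyl in place of hydrogen on an aromatic carbon para to a large group, this assay gives a number 5.6 percentage points lower from compound 2 to compound 3 (within the scatter), so this position now holds a substituent on the phenyl ring with no step beyond the scatter. Likewise, 4-ethylphenyl in place of pentyl gives a number 7.8 percentage points lower from compound 1 to compound 3 (within the scatter), which extends the earlier level reading to a substituted aryl group. No measurement at hand offers an explanation for these numbers. Going by these compounds, whether an amine, a carboxylic acid or a chain longer than ethyl on that aromatic carbon would move the number beyond the scatter remains open.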